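Cytotoxicity of an oxalamide series: one substituent swap

The source may hold more compounds than are shown below. What is called first, only, known or untested is meant among the compounds shown, and "the series" means these compounds.

compound 1 `Cc1nc(C(NC(=O)C(=O)Nc2ccc(F)cc2)C2CCCCN2)sc1CCO` — 109000 nM
compound 2 `Cc1nc(C(NC(=O)C(=O)Nc2ccc(Cl)cc2)C2CCCCN2)sc1CO` — > 108000 nM
compound 3 `Cc1nc(C(NC(=O)C(=O)Nc2ccc(C(F)(F)F)cc2)C2CCCCN2)sc1CO` — > 75500 nM

Among the measured compounds shown here, in an ADME assay on MT2 cells (Homo sapiens) for cytotoxicity, read by XTT assay, with a stated time of 4 days (a lower number here means that less compound is tolerated, a higher number that more compound is tolerated), compound 1 gives 109000 nM, the only number among the three values shown. For compound 2 the value > 108000 nM is a limit of the assay, not a number. For compound 3 the value > 75500 nM is likewise a limit. The step that the two limits leave unreadable from compound 2 to compound 3 cannot be read because of the limit of > 108000 nM in this assay, at which 1 of the 3 values shown sits, and (the limit of > 75500 nM in this assay, at which 1 of the 3 values shown sits).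

Compound 4 `Cc1ccc(NC(=O)C(=O)NC(c2nc(C)c(CCO)s2)C2CCCCN2)c(F)c1` differs from compound 1 by 2-fluoro-4-methylphenyl in place of 4-fluorophenyl on an amide-type nitrogen. For the measured compounds named here, no measured step carries this change, so nothing in the data points to a shift in either direction. Compound 4 is therefore expected to show a 1.1-fold lower number from compound 1 to compound 4 (0.04 log units; within the scatter), a step within the scatter. Compound 4 is estimated at 100000 nM, between 50000 nM and 200000 nM.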

Compound 4, half-maximal cytotoxic concentration: > 78800 nM
Compound 4 ended at the assay's limit; the forecaster's own chance of this, stated with the estimate: 40%; the middle value is on the limit's open side.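

In this assay, among the compounds shown here, compound 4 gives > 78800 nM, a limit of the assay and not a number, so no step between compound 1 and compound 4 can be read. The compounds shown leave open whether 2-fluoro-4-methylphenyl in place of 4-fluorophenyl shifts the result at all.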